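The source may report more compounds than this note shows. Statements on the series, on what has been measured and on what is new or still open speak of the compounds shown alone.

Series in a functional assay on CEM-DNR-bulk cells (Homo sapiens), read by MTT assay, with a stated time of 72 h (a higher number here means a weaker inhibitor, a lower number a stronger inhibitor), all entries limits:
- compound 1 `Nc1nc(N)c2c(-c3cc4ccccc4o3)cn([C@@H]3O[C@H](CO)[C@@H](O)[C@H]3O)c2n1`: limit, > 20000 nM
- compound 2 `COc1nc(N)nc2c1c(-c1ccoc1)cn2[C@@H]1O[C@H](CO)[C@@H](O)[C@H]1O`: limit, > 20000 nM
- compound 3 `COc1nc(N)nc2c1c(-c1cccs1)cn2[C@@H]1O[C@H](CO)[C@@H](O)[C@H]1O`: limit, > 20000 nM

Compound 3 has no numeric value, only the limit > 20000 nM. All data so far share one ceiling: the limit of > 20000 nM in this assay, at which 3 of the 3 values shown sit. Compound 4 `COc1nc(N)nc2c1c(-c1cc3ccccc3o1)cn2[C@@H]1O[C@H](CO)[C@@H](O)[C@H]1O` has 1-benzofuran-2-yl in place of thiophen-2-yl on an aromatic carbon.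

Within the data shown here, the only measured step, a step that the two limits leave unreadable from compound 2 to compound 3, gives neither size nor direction. Compound 1, which has 1-benzofuran-2-yl on another core, also reaches only a limit, > 20000 nM. No step beyond the scatter is therefore expected in this assay. The expected step is a number no higher from compound 3 to compound 4 (the limit leaves the size open). For compound 4 the estimate is 20000 nM, with an expected range from 8000 nM to 30000 nM.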

Compound 4, half-maximal inhibitory concentration: 16700 nM
Estimate against measurement, compound 4: 1.2-fold (0.08 log units) above, and the stated range covers the measured number.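

In this assay compound 4 gives the only number in the series, so a reading under the ceiling is possible with 1-benzofuran-2-yl on this aromatic carbon and methoxy on the shared core: the limit of > 20000 nM in this assay, at which 3 of the 4 values shown sit.

Placing 1-benzofuran-2-yl here gives an at least 1.1-fold lower number from compound 3 to compound 4 (0.07 log units; that floor lies within the scatter) and an at least 1.1-fold lower number from compound 2 to compound 4 (0.07 log units; that floor lies within the scatter), while methoxy in place of amino gives an at least 1.1-fold lower number from compound 1 to compound 4 (0.07 log units; that floor lies within the scatter). Each is only a floor within the scatter, and the step between the two limits cannot be read.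

As far as these compounds go, how far compounds 1, 2 and 3 actually lie from compound 4 stays open. So does the outcome with an amine or a carboxylic acid on this carbon.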